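Cyclobutyloxy in Place of Ethylsulfanyl at a Carbonyl Carbon

A few compounds are considered here, and "the series" means these few. Any claim that something is new, unique, unknown or untested is made for them only; others in the source may bear on it.

Compound 1 `CC1=C(C(=O)C2CC2)C(c2ccco2)NC(=O)N1`: in an assay on membranes from CHO cells for displacement of a labelled ligand from adenosine receptor A1 (Homo sapiens), read by scintillation counting, with a stated time of 60 min, tested at 1 uM (a lower number here means less inhibition, a higher number more inhibition at the concentration tested (going by the name of the read-out)), compound 1 gives 2%.
Compound 2 `CCNC(=O)C1=C(C)NC(=O)NC1c1ccco1`: in this assay compound 2 gives 2%.
Compound 3 `CCSC(=O)C1=C(C)NC(=O)NC1c1ccco1`: in this assay compound 3 gives 6%.

All three compounds share one core and differ only in the group on the carbonyl carbon. On the numbers as written, compound 3 has the largest of the three, but its separation from the others is slight: a number 4 percentage points higher from compound 1 to compound 3 (within the scatter) and a number 4 percentage points higher from compound 2 to compound 3 (within the scatter) both fall within the scatter of this assay, and no change at the digits printed from compound 1 to compound 2 (within the scatter) is flat as well. The three compounds therefore cannot be told apart on this read-out, and every substituent tried so far at this carbonyl carbon has left inhibition low.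

Compound 4 `CC1=C(C(=O)OC2CCC2)C(c2ccco2)NC(=O)N1` is the next member of the series. Its difference from compound 3 is cyclobutyloxy in place of ethylsulfanyl on a carbonyl carbon. The three steps above are the ones that bear on it, since each exchanged the group on the same carbonyl carbon, and none of them moved the number beyond the scatter. Among the measured compounds shown here, no measured step involves a cyclobutyloxy group or any ether on this carbon, so the expectation rests on the flatness of those three swaps alone. On that basis the step of a number 2 percentage points lower from compound 3 to compound 4 (within the scatter) is estimated to stay within the scatter. Compound 4 is therefore expected to give about 4% in this assay, with a range from -6% to 15%.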

Compound 4, a percentage reported as inhibition, at one concentration (the size of the read-out at that concentration, not a potency): 19%
Beside the measured number, compound 4's estimate is 15 percentage points below it; measured number above the stated range.
By their numbers in this assay, from the lowest: compounds 1, 2 and 3 (each within the scatter of the next); then compound 4.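

In this assay, among the compounds shown here, the cyclobutyloxy group gives the first steps beyond the scatter at this carbonyl carbon: a number 13 percentage points higher from compound 3 to compound 4 (beyond the scatter) where it replaces ethylsulfanyl, a number 17 percentage points higher from compound 2 to compound 4 (beyond the scatter) where it replaces ethylamino, and a number 17 percentage points higher from compound 1 to compound 4 (beyond the scatter) where it replaces cyclopropyl. The position therefore does not stay flat under every exchange, as the three earlier compounds alone had suggested, although the steps are modest and compound 4 gives 19% at the one concentration tested. No separate measurement accounts for this rise, so the numbers record the change without explaining it.

The exchange from ethylsulfanyl to cyclobutyloxy alters the atom attached to the carbonyl carbon and brings in the four-membered ring at once, so the compounds shown leave open which of these two changes goes with the higher number; an ethoxy or a cyclobutylsulfanyl group on the same carbon would separate them. Also open, on these data alone, is how a larger ring such as cyclohexyloxy or a longer chain such as hexyloxy would read here, and how far the rise extends beyond this single concentration.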